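Working notes on benzylated cinnamate amides

The compounds below may be only part of what the source reports. "The series", "measured", "known", "first", "only" and "open" are said of these compounds alone.

Measured so far:
compound 1 `COC(=O)/C=C/c1cccc(N(Cc2ccc(-c3ccc(F)c(F)c3)cc2)C(=O)C2CCCCC2)c1` — 72 nM
compound 2 `COC(=O)/C=C/c1cccc(NC(=O)C2CCCCC2)c1` — > 1000 nM

In an assay on isolated protein with Bile acid receptor (Homo sapiens) as the target (a higher number here means that more compound is needed for the effect, a lower number that less compound is needed), compound 1 gives 72 nM. Compound 2 shows only (the limit of > 1000 nM in this assay, at which 1 of the 2 values shown sits), which is a limit of the assay and not a number. Going by the values given here, compound 1 thus carries the only number in this assay, and the other value is a limit. Among the compounds with values here, no step between two measured compounds that differ in one place is available, so no measured step size can be quoted.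

Compound 3 `COC(=O)/C=C/c1cccc(N(Cc2ccc(-c3cccc(C(C)=O)c3)cc2)C(=O)C2CCCCC2)c1` is not yet measured. It differs from compound 1 as follows: 3-acetylphenyl in place of 3,4-difluorophenyl on an aromatic carbon. The place is para to a large group, and the rest of the shared core is unchanged. In this assay the expected step is small, if anything toward a slightly higher number, and probably not beyond the scatter. Compound 3 is estimated at 150 nM, within 40 nM to 600 nM. The step implied by this estimate, a 2.1-fold higher number from compound 1 to compound 3 (0.32 log units; beyond the scatter), is expected to be modest.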

Compound 3, half-maximal effective concentration: 227 nM
The estimate for compound 3 lay 1.5-fold (0.18 log units) below the measured number; the measured number falls inside the stated range.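

In this assay this position now has its first measured step, with 3-acetylphenyl in place of 3,4-difluorophenyl on an aromatic carbon: a 3.2-fold higher number from compound 1 to compound 3 (0.50 log units; beyond the scatter). The outer aromatic ring can therefore be changed with a modest step beyond the scatter, and the step size at this place is no longer unknown. None of the available data gives a cause for this step.

As far as these compounds go, the change removes both fluorines and adds the acetyl group at once, so the part played by each remains open. Also open, from the compounds shown here alone, is how a carboxylic acid or an amine at the same place would read in this assay, as one replacement defines no trend for this position.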